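Chalcone-type series: thiophene replacement at the carbonyl

The source may report more compounds than this note shows. Statements on the series, on what has been measured and on what is new or still open speak of the compounds shown alone.

Measured so far:
- compound 1, `COc1ccc(-c2cc3ccccc3nc2/C=C/C(=O)c2ccc(OC)c(OC)c2)cc1`: 1050 nM
- compound 2, `COc1ccc(-c2cc3ccccc3nc2/C=C/C(=O)c2ccc(Br)s2)cc1`: 710 nM

Both numbers come from a functional assay on NCI-H1299 cells (Homo sapiens) for antiproliferative activity, read by XTT assay, with a stated time of 72 h; on this read-out lower numbers stand for stronger inhibition and higher numbers for weaker inhibition. Compound 2 gives the lower of the two, yet the step of a 1.5-fold lower number from compound 1 to compound 2 (0.17 log units; within the scatter) lies within the scatter, so the two compounds cannot be separated on these data.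

Compound 3, `COc1ccc(-c2cc3ccccc3nc2/C=C/C(=O)c2ccsc2)cc1`, is not yet measured. It differs from compound 2 by thiophen-3-yl in place of 5-bromothiophen-2-yl on a carbonyl carbon. Going by the values given here, the only measured step that bears on this change is the exchange of the aryl group on the carbonyl carbon, a 1.5-fold lower number from compound 1 to compound 2 (0.17 log units; within the scatter), which was within the scatter. A second exchange at the same carbonyl carbon is therefore expected to move the number little, with no clear direction; loss of the bromine is an untested element and widens the range.

The estimate for compound 3 in this assay is 1000 nM (range 400 nM to 2500 nM). The expected step from compound 2 is a 1.4-fold higher number from compound 2 to compound 3 (0.15 log units; within the scatter).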

Compound 3, half-maximal inhibitory concentration: 1220 nM
Compound 3: middle estimate off by 1.2-fold (0.09 log units), on the low side; low and high end bracket the measured number.
By their numbers in this assay, from the lowest: compounds 2, 1 and 3 (each within the scatter of the next).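

Thiophen-3-yl in place of 5-bromothiophen-2-yl on the carbonyl carbon gives a 1.7-fold higher number from compound 2 to compound 3 (0.24 log units; within the scatter) in this assay and so does not separate the two thiophenes. Thiophen-3-yl in place of 3,4-dimethoxyphenyl gives a 1.2-fold higher number from compound 1 to compound 3 (0.07 log units; within the scatter) as well, so all three groups shown at this carbon now lie within the scatter of one another, with or without the bromine.

In the step from compound 2 to compound 3, the bromine and the thiophene attachment point change together, so neither change can be read alone. Also open, from the compounds shown here alone, is whether a different kind of group on this carbonyl carbon, such as a phenyl ring carrying a carboxylic acid or a dimethylamino group, would separate from these three.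

No measurement at hand explains these numbers.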